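Nitro Substitution Carried From One Core to a Second

The source may report more compounds than this note shows. Statements on the series, on what has been measured and on what is new or still open speak of the compounds shown alone.

All numbers below come from a functional assay on HepG2 cells (Homo sapiens) for antiproliferative activity, read by fluorescence and resazurin assay, with a stated time of 48 h; a higher number here means a weaker inhibitor, a lower number a stronger inhibitor.

Compound 1 `CCOc1ccc2nc(Cl)c(/C=N/NC(=O)c3cc4cc([N+](=O)[O-])ccc4oc3=O)cc2c1` gives 18100 nM.
Compound 2 `CCOc1ccc2nc(Cl)c(/C=N/NC(=O)c3cc4ccccc4oc3=O)cc2c1` gives 33100 nM.
Compound 3 `Cc1noc(NS(=O)(=O)c2ccc(NC(=O)c3cc4ccccc4oc3=O)cc2)c1C` gives 24000 nM.

The three measured compounds lie within the scatter of one another in this assay, so no order among them is claimed. Compound 2 and compound 3 carry different cores; the difference between the two cores is not broken down here. On the core of compound 2, the change to compound 1 is nitro in place of hydrogen on an aromatic carbon, and it produced a 1.8-fold lower number from compound 2 to compound 1 (0.26 log units; within the scatter).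

Compound 4 `Cc1noc(NS(=O)(=O)c2ccc(NC(=O)c3cc4cc([N+](=O)[O-])ccc4oc3=O)cc2)c1C`, not yet measured, applies the same change to the core of compound 3: nitro in place of hydrogen on an aromatic carbon. The place is described in the same words for both pairs, so this is treated as the same kind of change on a different core.

Going by the values given here, because the single prior instance gave a 1.8-fold lower number from compound 2 to compound 1 (0.26 log units; within the scatter), a step of similar size is expected here, estimated as a 1.6-fold lower number from compound 3 to compound 4 (0.20 log units; within the scatter). That rests on one pair only, and on a step that itself lies within the scatter. For compound 4 the estimate is 15000 nM, with a likely range from 6000 nM to 40000 nM.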

Compound 4, half-maximal inhibitory concentration: 15000 nM
Beside the measured number, compound 4's estimate shows no gap at the digits printed, and the stated range covers the measured number.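

In this assay, nitro in place of hydrogen on an aromatic carbon gave a 1.6-fold lower number from compound 3 to compound 4 (0.20 log units; within the scatter) on the second core. Set beside the earlier step, the two cores give steps that cannot be told apart: the same change on two cores in this assay, a 1.8-fold lower number (0.26 log units; within the scatter) from compound 2 to compound 1 and a 1.6-fold lower number (0.20 log units; within the scatter) from compound 3 to compound 4, 1.1-fold (0.06 log units) apart, within the scatter of two such steps

The change therefore carries across these two cores without any detectable difference in step size, but each step lies within the scatter on its own, so the two pairs do not establish that nitro alters the antiproliferative reading on either core, and they say nothing about any further core.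

The compounds shown leave open whether any other group in the same place, such as an amine, a carboxylic acid or a methoxy group, would give a step beyond the scatter. They also leave open how nitro would read elsewhere on the six-membered aromatic ring, since only one place is represented in both pairs.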